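The compounds below may be only part of what the source reports. "The series", "measured", "known", "first", "only" and "open" are said of these compounds alone.

Measured in a functional assay on MCF7 cells (Homo sapiens) for antiproliferative activity, read by sulforhodamine B assay, with a stated time of 48 h; a higher number here means a weaker inhibitor, a lower number a stronger inhibitor:
- compound 1 `CCc1ccccc1OS(=O)(=O)c1ccc(N2CCN(C)C2=O)cc1`: 26000 nM
- compound 2 `CN1CCN(c2ccc(S(=O)(=O)Oc3cccc(Cl)c3)cc2)C1=O`: 2200 nM
- compound 3 `CN1CCN(c2ccc(S(=O)(=O)Oc3cccc(Br)c3)cc2)C1=O`: 1500 nM

Compound 3 stands with compound 2 at the low end of these numbers: a 1.5-fold lower number from compound 2 to compound 3 (0.17 log units; within the scatter), while a 17-fold lower number from compound 1 to compound 3 (1.24 log units; beyond the scatter). Compound 4 `Cc1ccc(OS(=O)(=O)c2ccc(N3CCN(C)C3=O)cc2)cc1` has 4-methylphenyl in place of 3-bromophenyl on an oxygen. Among the measured compounds shown here, no measured step makes this exact change, and no measured compound carries 4-methylphenyl. The closest evidence is a 12-fold lower number from compound 1 to compound 2 (1.07 log units; beyond the scatter), along with a 17-fold lower number from compound 1 to compound 3 (1.24 log units; beyond the scatter), which shows that changing the group on this oxygen can move the number considerably. A moderate rise in this assay is therefore expected, not a change as large as those. The expected step is a 3.3-fold higher number from compound 3 to compound 4 (0.52 log units; beyond the scatter). For compound 4 the estimated value is 5000 nM, with an expected range of 1500 nM to 20000 nM.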

Compound 4, half-maximal inhibitory concentration: > 100000 nM
Compound 4: no number, only a limit; the forecaster's own chance of this, stated with the estimate: 10%; middle value at least 20-fold (1.30 log units) from the limit.
By their numbers in this assay, from the lowest: compounds 3 and 2 (each within the scatter of the next); then compound 1. At a limit, above all of these: compound 4.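

Compound 4 gives no number in this assay, only a limit: the limit of > 100000 nM in this assay, at which 1 of the 4 values shown sits. On this oxygen, 4-methylphenyl in place of the halogen-bearing groups gives an at least 66-fold higher number from compound 3 to compound 4 (1.82 log units; beyond the scatter) and an at least 45-fold higher number from compound 2 to compound 4 (1.65 log units; beyond the scatter), so the group here can move the number further than any earlier step showed. Even the 2-ethylphenyl group keeps more activity, with an at least 3.8-fold higher number from compound 1 to compound 4 (0.58 log units; beyond the scatter), so compound 1 did not mark the weak end of this position.

As far as these compounds go, it remains open whether the methyl group or its ring position accounts for the loss; a 3-methylphenyl or a 4-bromophenyl group on this oxygen would separate the two.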